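Methoxy added to the benzyl of compound 2

The compounds below may be only part of what the source reports. "The series", "measured", "known", "first", "only" and "open" are said of these compounds alone.

Measured so far:
compound 1 `COc1ccccc1Cc1cc2c(N)nc(-c3ccc(C)o3)nc2s1` — 122 nM
compound 2 `N#Cc1cccc(-c2nc(N)c3cc(Cc4ccccc4)sc3n2)c1` — 222 nM

In a functional assay on CHO-K1 cells for antagonist activity at adenosine receptor A1 (Homo sapiens), read by a beta-galactosidase reporter and cAMP accumulation, with stated times of 15 min and 6 h (a lower number here means a stronger inhibitor, a higher number a weaker inhibitor), compound 2 gives 222 nM, the higher of the two numbers; compound 1 gives 122 nM, and the gap between the two lies within the scatter. Compound 3 `COc1ccccc1Cc1cc2c(N)nc(-c3cccc(C#N)c3)nc2s1` differs from compound 2 by methoxy in place of hydrogen on an aromatic carbon on the benzyl, the nitrile-bearing aryl being kept. For the measured compounds named here, no measured pair isolates this change, so the series gives no direction for it; a step beyond the scatter is not expected. Compound 3 is estimated at 160 nM, with a range from 60 nM to 420 nM. The expected step is a 1.4-fold lower number from compound 2 to compound 3 (0.14 log units; within the scatter).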

Compound 3, inhibition constant: 129 nM
The estimate for compound 3 lay 1.2-fold (0.09 log units) above the measured number; the measured number falls inside the stated range.
By their numbers in this assay, from the lowest: compounds 1, 3 and 2 (each within the scatter of the next).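

In this assay, methoxy in place of hydrogen on the benzyl gives a 1.7-fold lower number from compound 2 to compound 3 (0.24 log units; within the scatter) and so reads as a change that is tolerated with the nitrile-bearing aryl kept, with no shift that can be told from noise. With the 2-methoxybenzyl held, 3-cyanophenyl in place of 5-methylfuran-2-yl gives a 1.1-fold higher number from compound 1 to compound 3 (0.02 log units; within the scatter) and leaves the two aryl groups indistinguishable here. No evidence on either change is available. Open, as far as these compounds go, is whether an ethoxy, an amine or a carboxylic acid on this aromatic carbon would move the number beyond the scatter.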